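The compounds below may be only part of what the source reports. "The series", "measured", "known", "first", "only" and "open" are said of these compounds alone.

In an assay on HEK293 cells for positive allosteric modulation of metabotropic glutamate receptor 3 (Rattus norvegicus), read by thallium flux, with a stated time of 2.5 min (a higher number here means that more compound is needed for the effect, a lower number that less compound is needed), compound 1 `Cc1c(OCCCCOc2ccc(C(=O)O)cc2)ccc(C(=O)CC(C)C)c1O` gives 2720 nM. Compound 2 `Cc1c(OCCCCOc2ccc(F)c(C(=O)O)c2)ccc(C(=O)C(C)C)c1O` gives > 10000 nM, which is a limit of this assay rather than a number. Compound 2 therefore stands at the limit of > 10000 nM in this assay, at which 1 of the 2 values shown sits. Compound 3 `Cc1c(OCCCCOc2ccc(F)c(C(=O)O)c2)ccc(C(=O)CC(C)C)c1O` differs from compound 2 in a single place: isobutyl in place of isopropyl on a carbonyl carbon. Among the compounds with values here, no measured pair shows this change by itself, so the size of the step is open; a move toward less compound needed is expected, though it may stay within the scatter. The step expected here is an at least 1.6-fold lower number from compound 2 to compound 3 (0.22 log units; that floor lies within the scatter). Compound 3 is estimated at 6000 nM, with a range from 2500 nM to 20000 nM.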

Compound 3, half-maximal effective concentration: 920 nM
Beside the measured number, compound 3's estimate is 6.5-fold (0.81 log units) above it, and the stated range ends above it.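

Putting isobutyl in place of isopropyl on the carbonyl carbon, with nothing else changed, gives an at least 10-fold lower number from compound 2 to compound 3 (1.03 log units; beyond the scatter), so this position responds strongly to a small change in the chain. Compound 2 stands at a limit of the assay, not at a number: the limit of > 10000 nM in this assay, at which 1 of the 3 values shown sits.

With isobutyl kept, the aromatic group matters too: 3-carboxy-4-fluorophenyl in place of 4-carboxyphenyl gives a 3.0-fold lower number from compound 1 to compound 3 (0.47 log units; beyond the scatter). Going by these compounds, whether a longer chain or a cyclopentyl group on the carbonyl carbon would lower the number further stays open. Also open, on these data alone, is whether the fluoro group or the place of the carboxy group accounts for that second step.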